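Working notes: from dimethylphenyl to dichlorophenyl on the carbonyl

The source may hold more compounds than are shown below. What is called first, only, known or untested is meant among the compounds shown, and "the series" means these compounds.

- compound 1 `Cc1cc(S(N)(=O)=O)ccc1NC(=O)COc1ccc(Cl)cc1NC(=O)c1ccccc1C` gives 67300 nM
- compound 2 `Cc1ccc(C)c(C(=O)Nc2cc(Cl)ccc2OCC(=O)Nc2ccc(S(N)(=O)=O)cc2C)c1` gives 79700 nM
- compound 3 `Cc1cc(C)cc(C(=O)Nc2cc(Cl)ccc2OCC(=O)Nc2ccc(S(N)(=O)=O)cc2C)c1` gives 36500 nM

In a functional assay on C8166 cells (Homo sapiens) for cytotoxicity, read by MTT assay (on this read-out lower numbers stand for higher toxicity in this test and higher numbers for lower toxicity in this test), compound 3 reads 36500 nM and sits at the low end of these numbers together with compound 1 (a 1.8-fold lower number from compound 1 to compound 3 (0.27 log units; within the scatter)), while compound 2 stands apart (a 2.2-fold lower number from compound 2 to compound 3 (0.34 log units; beyond the scatter)). Compound 4 `Cc1cc(S(N)(=O)=O)ccc1NC(=O)COc1ccc(Cl)cc1NC(=O)c1cc(Cl)cc(Cl)c1` carries 3,5-dichlorophenyl in place of 3,5-dimethylphenyl on a carbonyl carbon. For the measured compounds named here, no measured step brings in chlorine, so the data offer no direct precedent. The nearest evidence is a 1.2-fold higher number from compound 1 to compound 2 (0.07 log units; within the scatter) and a 2.2-fold lower number from compound 2 to compound 3 (0.34 log units; beyond the scatter) and neither is more than modest, so no step beyond the scatter is expected in this assay and no direction is favoured. The estimated step (a 1.1-fold higher number from compound 3 to compound 4 (0.04 log units; within the scatter)) is therefore small. Compound 4 is estimated at 40000 nM with an expected range from 18000 nM to 85000 nM.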

Compound 4, half-maximal cytotoxic concentration: 72400 nM
Beside the measured number, compound 4's estimate is 1.8-fold (0.26 log units) below it; low and high end bracket the measured number.
By their numbers in this assay, from the lowest: compounds 3, 1, 4 and 2 (each within the scatter of the next, the first and the last beyond it).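

Bringing chlorine onto the aryl group on the carbonyl carbon gives, in this assay, a 2.0-fold higher number from compound 3 to compound 4 (0.30 log units; within the scatter), alongside a 1.1-fold lower number from compound 2 to compound 4 (0.04 log units; within the scatter) and a 1.1-fold higher number from compound 1 to compound 4 (0.03 log units; within the scatter). All three steps lie within the scatter, so compound 4 cannot be separated from compound 1, compound 2 or compound 3. At this position, 3,5-dichlorophenyl therefore reads no differently from the methyl-bearing aryl groups in this test.

Going by these compounds, whether an amine or a carboxylic acid on this aryl group would shift the number beyond the scatter remains open. Nothing available here offers an explanation for these readings.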